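Ring Nitrogen Position and Plasma Half-Life of Salicylate Diesters

The source may hold more compounds than are shown below. What is called first, only, known or untested is meant among the compounds shown, and "the series" means these compounds.

Measured compounds:
Compound 1, `CC(=O)Oc1ccccc1C(=O)O[C@H]1CO[C@H]2[C@@H]1OC[C@H]2OC(C)=O`: 0.0608 h
Compound 2, `CC(=O)Oc1ccccc1C(=O)O[C@H]1CO[C@H]2[C@@H]1OC[C@H]2OC(=O)c1ccc([N+](=O)[O-])cc1`: 0.0462 h
Compound 3, `CC(=O)Oc1ccccc1C(=O)O[C@H]1CO[C@H]2[C@@H]1OC[C@H]2OC(=O)c1cccnc1`: 0.0232 h

Three compounds of a shared core were tested in an ADME assay on a cell-free system (plasma, Homo sapiens) for metabolic stability, with Plasma (Rattus norvegicus) as the target, read by HPLC, at pH 7.4; on this read-out higher numbers stand for a longer-lived compound and lower numbers for a shorter-lived compound. Compound 3 gives the lowest of the three numbers, yet its gap to compound 2 lies within the scatter, so only compound 1 stands clearly apart from it, as the step of a 2.6-fold lower number from compound 1 to compound 3 (0.42 log units; beyond the scatter) shows. The other steps, a 1.3-fold lower number from compound 1 to compound 2 (0.12 log units; within the scatter) and a 2.0-fold lower number from compound 2 to compound 3 (0.30 log units; within the scatter), fall within the scatter.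

Compound 4, `CC(=O)Oc1ccccc1C(=O)O[C@H]1CO[C@H]2[C@@H]1OC[C@H]2OC(=O)c1ccncc1`, has not yet been measured. It differs from compound 3 in one place: pyridin-4-yl in place of pyridin-3-yl on a carbonyl carbon. Within the data shown here, none of the measured steps moves the ring nitrogen within a pyridyl group; the steps into compound 3 only exchange a methyl or a 4-nitrophenyl for pyridin-3-yl, and those amounted at most to a modest lowering. The data therefore give no reason to expect a step beyond the scatter in this assay for compound 4. Its half-life is estimated at 0.025 h, within a range of 0.012 h to 0.052 h, which means an expected step of a 1.1-fold higher number from compound 3 to compound 4 (0.03 log units; within the scatter).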

Compound 4, half-life: 0.0617 h
For compound 4 the middle estimate is 2.5-fold (0.39 log units) below the measured one; the whole stated range lies below it.
By their numbers in this assay, from the lowest: compounds 3, 2, 1 and 4 (each within the scatter of the next, the first and the last beyond it).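

The exchange of pyridin-3-yl for pyridin-4-yl on this carbonyl carbon gives a 2.7-fold higher number from compound 3 to compound 4 (0.42 log units; beyond the scatter) in this assay although the two groups have the same atoms and the same counts, so the half-life at this position depends on where the ring nitrogen stands and not on the presence of a pyridyl group alone. The lowering seen with pyridin-3-yl therefore does not extend to pyridyl groups as a whole: compound 4 gives a 1.0-fold higher number from compound 1 to compound 4 (0.01 log units; within the scatter) against the methyl ester and a 1.3-fold higher number from compound 2 to compound 4 (0.13 log units; within the scatter) against the 4-nitrophenyl ester, and both steps lie within the scatter. Nothing shown here explains why the two pyridyl isomers part in this way.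

On these data alone, it remains open whether a plain phenyl group, a pyrimidin-5-yl group or a longer chain on the same carbonyl carbon would fall with compound 3 or with compound 4. As far as these compounds go, it also remains open whether an amino or a methoxy group on the pyridin-4-yl ring would leave the half-life where compound 4 has it.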